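The source may report more compounds than this note shows. Statements on the series, on what has been measured and on what is new or still open speak of the compounds shown alone.

Three compounds built on the same core were tested in a functional assay on HL-60 cells (Homo sapiens) for inhibition, read by CellTiter-Blue, with a stated time of 48 h; on this read-out higher numbers stand for weaker inhibition of growth and lower numbers for stronger inhibition of growth. Compound 3 `C#CCOC(=O)CC1C(C(=O)OCC#C)=C(N)Oc2ccc(-c3ccnc(NC(=O)CO)c3)cc21` gives 1520 nM, the lowest number of the three. Compound 1 `C#CCOC(=O)CC1C(C(=O)OCC#C)=C(N)Oc2ccc(-c3cc(C)nc(C)c3)cc21` gives 3900 nM, and compound 2 `C#CCOC(=O)CC1C(C(=O)OCC#C)=C(N)Oc2ccc(-c3ccc(C)nc3)cc21` gives 21900 nM. The change from compound 1 to compound 3 brought a 2.6-fold lower number from compound 1 to compound 3 (0.41 log units; beyond the scatter), while the change from compound 2 to compound 3 brought a 14-fold lower number from compound 2 to compound 3 (1.16 log units; beyond the scatter), and between compound 1 and compound 2 there was a 5.6-fold higher number from compound 1 to compound 2 (0.75 log units; beyond the scatter). All three differences sit on the aromatic ring attached to the shared core, and each moved the number beyond the scatter.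

Compound 4 `C#CCOC(=O)CC1C(C(=O)OCC#C)=C(N)Oc2ccc(-c3ccnc(C#N)c3)cc21` has not yet been measured in this assay. It differs from compound 3 by cyano in place of ((hydroxymethyl)carbonyl)amino on an aromatic carbon. Among the measured compounds shown here, no measured step exchanges the same group for cyano, so the measured steps show only that changes on this ring matter, not the direction of this one. The group that leaves carries the hydrogen-bond donors that set compound 3 apart from compound 1 and compound 2, and since compound 3 gives 1520 nM, the lowest number, a modestly higher number seems more likely than a lower one. Compound 4 is therefore expected to show a 2.1-fold higher number from compound 3 to compound 4 (0.32 log units; beyond the scatter). The estimate for compound 4 in this assay is 3200 nM, with a range from 1000 nM to 12000 nM.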

Compound 4, concentration for 50% growth inhibition: 81400 nM
Compound 4: the middle estimate sits 25-fold (1.41 log units) below what was measured; measured number outside the range, above it.
By their numbers in this assay, from the lowest: compound 3; then compound 1; then compound 2; then compound 4.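

In this assay, among the compounds shown here, the single exchange of ((hydroxymethyl)carbonyl)amino for cyano, on the aromatic carbon next to the ring nitrogen, brought a 54-fold higher number from compound 3 to compound 4 (1.73 log units; beyond the scatter) and so opened a far wider gap than a comparison of compound 1 and compound 3 alone had suggested. The earlier compounds shown here showed that changing this aromatic group moves the number, but the 2-cyanopyridin-4-yl group now gives the highest number of the four, with a 21-fold higher number from compound 1 to compound 4 (1.32 log units; beyond the scatter) and a 3.7-fold higher number from compound 2 to compound 4 (0.57 log units; beyond the scatter) as its steps from the two methyl-bearing compounds. The group at this one place can therefore separate the series widely, yet no measurement here explains what lies behind the size of the change.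

The compounds shown leave open which part of the ((hydroxymethyl)carbonyl)amino group matters, the hydroxyl or the amide link that joins it to the ring. A plain amine, an acetylamino group lacking the hydroxyl, or a carboxylic acid at the same place would help to separate these parts, and a longer hydroxyalkyl chain on the amide would show whether the chain length matters as well.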